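Replacing the 4-methoxycyclohexyl group of compound 3

The compounds below may be only part of what the source reports. "The series", "measured", "known", "first", "only" and "open" are said of these compounds alone.

Of the compounds shown here, three have been tested so far in a physicochemical assay for solubility (a higher number here means a more soluble compound, a lower number a less soluble compound), and none has yet returned an exact number. Compound 1 `CCNC(=O)c1cc(C(=O)NC)nn1[C@@H](C)c1ccccc1` gives >= 137 ug/mL, which is a limit of the assay. Compound 2 `CNC(=O)c1cc(C(=O)N[C@H]2[C@@H]3COC[C@@H]32)c([C@@H](C)c2ccccc2)o1` gives >= 131 ug/mL, which is also a limit. Compound 3 `CNC(=O)c1cc(C(=O)N[C@H]2CC[C@H](OC)CC2)c([C@@H](C)c2ccccc2)o1` stands at >= 192 ug/mL, again a limit, and this is all that is known of it.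

Compound 4 `CNC(=O)c1cc(C(=O)N[C@H]2[C@@H]3C[C@@H](O)C[C@@H]32)c([C@@H](C)c2ccccc2)o1` differs from compound 3 on an amide-type nitrogen: a group of 7 heavy atoms (6 carbon, 1 oxygen; one three-membered non-aromatic ring of carbon only, one five-membered non-aromatic ring of carbon only) in place of a group of 8 heavy atoms (7 carbon, 1 oxygen; one six-membered non-aromatic ring of carbon only), on an amide-type nitrogen. For the measured compounds named here, the only measured step that bears on this change is a step that the two limits leave unreadable from compound 2 to compound 3, also an exchange of groups on an amide-type nitrogen. It offers no size to carry over, so no step beyond the usual scatter is expected in this assay, in either direction. The expected step is an at least 1.0-fold lower number from compound 3 to compound 4 (0.02 log units; that floor lies within the scatter). The estimate for compound 4 is 180 ug/mL, with an expected range from 100 ug/mL to 260 ug/mL.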

Compound 4, solubility: >= 172 ug/mL
Compound 4 gave a limit, no number (the forecaster's own chance of this, stated with the estimate: 75%); the middle value does not contradict the limit.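

In this assay compound 4 gives >= 172 ug/mL, which is a limit and not a number. With limits on both sides, neither the step from compound 3 to compound 4 nor the step from compound 2 to compound 4 can be read. The compounds shown leave open what the exact solubility of each compound is, and whether exchanging the group on the amide-type nitrogen changes it at all.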